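One Swap on Two Cores: Phenyl for Methyl

A few compounds are considered here, and "the series" means these few. Any claim that something is new, unique, unknown or untested is made for them only; others in the source may bear on it.

Compound 1, `COC(=O)c1c(O)c2ccccc2n(C)c1=O`, gives 7.4%.
Compound 2, `COC(=O)c1c(O)c2ccccc2n(-c2ccccc2)c1=O`, gives 9.1%.
Compound 3, `Cn1c(=O)c(C(=O)Nc2ccccc2N)c(O)c2ccccc21`, gives 13.5%.

These three compounds were tested in a functional assay, with a stated time of 60 min, tested at 0.1 mM; a lower number here means a weaker effect, a higher number a stronger effect of the compound at the concentration tested. Compound 1 and compound 2 share a core and differ in one place: phenyl in place of methyl on an aromatic nitrogen. This change produced a number 1.7 percentage points higher from compound 1 to compound 2 (within the scatter), so the two values cannot be told apart by this measurement.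

Compound 3 carries a different core; how its core differs from that of compound 1 is not broken down here. Compound 3 stands at the highest of the three numbers, yet its gaps to compound 2 and to compound 1 both lie within the scatter, so no ordering among the three can be claimed.

Compound 4, `Nc1ccccc1NC(=O)c1c(O)c2ccccc2n(-c2ccccc2)c1=O`, has not yet been measured. It relates to compound 3 as compound 2 relates to compound 1: phenyl in place of methyl on an aromatic nitrogen. The surroundings are not identical, though: in compound 1 the aromatic nitrogen sits meta to a methoxycarbonyl group, whereas in compound 3 it sits meta to a large group. The change is therefore the same kind of change, not the same change.

Because the step of a number 1.7 percentage points higher from compound 1 to compound 2 (within the scatter) stayed within the scatter, a similarly small step is expected for compound 4. The estimated step is a number 1.5 percentage points higher from compound 3 to compound 4 (within the scatter), resting on compound 3 and its value 13.5% as the starting point. Compound 4 is expected to give about 15% in this assay, most likely between 5% and 27%.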

Compound 4, a percentage reported as activity, at one concentration (the size of the read-out at that concentration, not a potency): 16.3%
For compound 4 the middle estimate is 1.3 percentage points below the measured one; the range from low to high includes it.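

In this assay, phenyl in place of methyl on an aromatic nitrogen gave a number 2.8 percentage points higher from compound 3 to compound 4 (within the scatter), while (2-aminophenyl)amino in place of methoxy on a carbonyl carbon, the change that separates the two phenyl compounds, gave a number 7.2 percentage points higher from compound 2 to compound 4 (within the scatter). As far as this measurement can tell, the phenyl swap behaved the same way on the two cores: the same change on two cores in this assay, a number 1.7 percentage points higher (within the scatter) from compound 1 to compound 2 and a number 2.8 percentage points higher (within the scatter) from compound 3 to compound 4, 1.1 percentage points apart, within the scatter of two such steps. This shows that the swap carried over from one core to the other without a visible difference, but it does not show that the swap has no effect at all, since any effect of that size would stay hidden in the scatter, and two cores cannot speak for the whole series.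

The compounds shown leave open what a longer chain, such as a propyl group, or a benzyl group would give on the same aromatic nitrogen, and whether a carboxylic acid in place of the ester or the amide would move the read-out beyond the scatter. Going by these compounds, each compound also appears with a read-out at a single concentration, so how the compounds would compare at other concentrations remains open as well.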